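This account rests on a few compounds, and the source may have more. Where it says the series, first, only, none or still open, it means among the compounds named here.

Compound 1 `CCn1c(N)c(-c2nc3ccccc3[nH]2)c2nc(C#N)c(C#N)nc21`: > 50000 nM
Compound 2 `N#Cc1nc2c(-c3nc4ccccc4[nH]3)c(N)n(CCN3CCCC3)c2nc1C#N`: > 50000 nM
Compound 3 `N#Cc1nc2c(-c3nc4ccccc4[nH]3)c(N)n(CCO)c2nc1C#N`: > 50000 nM

In a functional assay on A549 cells (Homo sapiens) for antiproliferative activity, read by MTT assay, with a stated time of 48 h (a lower number here means a stronger inhibitor, a higher number a weaker inhibitor), compound 3 gives > 50000 nM, which is a limit and not a number. It shares that position with the other two compounds: the limit of > 50000 nM in this assay, at which 3 of the 3 values shown sit.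

Compound 4 `CCN(CC)CCCn1c(N)c(-c2nc3ccccc3[nH]2)c2nc(C#N)c(C#N)nc21` differs from compound 3 by (diethylamino)methyl in place of hydroxy on a saturated chain carbon, two bonds along the chain from an aromatic nitrogen. In words, (diethylamino)methyl stands in place of hydroxy on a saturated chain carbon, two bonds along the chain from an aromatic nitrogen, so 2-hydroxyethyl becomes 3-(diethylamino)propyl.

Going by the values given here, three measured steps concern this chain: a step that the two limits leave unreadable from compound 1 to compound 2, a step that the two limits leave unreadable from compound 1 to compound 3 and a step that the two limits leave unreadable from compound 2 to compound 3. None of them gives a size that could be carried over.

Compound 2, with its pyrrolidin-1-yl chain, stays at > 50000 nM, also a limit. No clear gain in this assay is therefore expected, though any movement would more likely be towards stronger inhibition. The expected change is an at least 1.1-fold lower number from compound 3 to compound 4 (0.04 log units; that floor lies within the scatter). Compound 4 is estimated at 45000 nM, with an expected range from 8000 nM to 80000 nM.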

Compound 4, half-maximal inhibitory concentration: 25300 nM
Estimate against measurement, compound 4: 1.8-fold (0.25 log units) above; the measured number falls inside the stated range.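

In this assay, the 3-(diethylamino)propyl chain of compound 4 gives the first readable number at this position, where the steps among the three earlier compounds cannot be read: the limit of > 50000 nM in this assay, at which 3 of the 4 values shown sit.

The new steps are only floors: an at least 1.9-fold lower number from compound 3 to compound 4 (0.29 log units; that floor lies within the scatter), an at least 1.9-fold lower number from compound 2 to compound 4 (0.29 log units; that floor lies within the scatter) and an at least 1.9-fold lower number from compound 1 to compound 4 (0.29 log units; that floor lies within the scatter). An amine on the chain is not enough to leave the limit, as compound 2 goes against any such pattern with its pyrrolidin-1-yl chain.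

Going by these compounds, how large the steps really are remains open, since each starts from a limit. Compound 4 also differs from compound 2 in both its amine and its chain length, so a 2-(diethylamino)ethyl or a 3-(pyrrolidin-1-yl)propyl chain would be needed to tell these two changes apart.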